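Cytotoxicity notes on the uracil-pentyloxyphenyl series

A few compounds are considered here, and "the series" means these few. Any claim that something is new, unique, unknown or untested is made for them only; others in the source may bear on it.

Measured compounds:
compound 1 `CC(C)c1ccc(OCCCCCn2ccc(=O)[nH]c2=O)cc1` — > 100000 nM
compound 2 `CCCOC(=O)c1ccc(OCCCCCn2ccc(=O)[nH]c2=O)cc1` — > 100000 nM
compound 3 `O=c1ccn(CCCCCOc2ccc(Cl)cc2)c(=O)[nH]1` — "not determined" (no result reported)

In an ADME assay on HEL cells (Homo sapiens) for cytotoxicity (on this read-out lower numbers stand for higher toxicity in this test and higher numbers for lower toxicity in this test), compound 1 gives > 100000 nM, a limit of the assay. In this assay compound 2 gives > 100000 nM, also a limit. The step that the two limits leave unreadable from compound 1 to compound 2 is therefore unreadable. For compound 3 no result is reported in this assay, so it stands apart from the two limits, which sit at the limit of > 100000 nM in this assay, at which 2 of the 3 values shown sit.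

Compound 4 `Nc1ccc(OCCCCCn2ccc(=O)[nH]c2=O)cc1` differs from compound 3 by amino in place of chloro on an aromatic carbon. Among the measured compounds shown here, no measured step bears directly on this change; the only counted step is unreadable. Given that both readable neighbours sit at the limit, compound 4 is expected to show low toxicity, estimated at 100000 nM (range 30000 nM to 300000 nM), most likely again as a limit.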

Compound 4, half-maximal cytotoxic concentration: > 100000 nM
Compound 4: no number, only a limit; the forecaster's own chance of this, stated with the estimate: 70%; the middle value lies on the limit itself.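

In this assay compound 4 gives > 100000 nM, a limit of the assay. Its steps from compound 1 and compound 2 therefore cannot be read. The compounds shown leave open whether changing the group on the aromatic carbon shifts cytotoxicity at all.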